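The compounds below may be only part of what the source reports. "The series", "measured", "known", "first", "only" and "open" are said of these compounds alone.

Working notes on the series. The three measured compounds share one core and differ only in the group on a single aromatic carbon. In a functional assay on A549 cells (Homo sapiens), read by MTT assay, with a stated time of 3 days (a lower number here means a stronger inhibitor, a higher number a weaker inhibitor), compound 1 `Nc1ncnc2[nH]cc(Sc3cccs3)c12` gives 22800 nM, compound 2 `c1csc(Sc2c[nH]c3ncnc(-c4cccs4)c23)c1` gives 16200 nM, and compound 3 `c1coc(-c2ncnc3[nH]cc(Sc4cccs4)c23)c1` gives 11400 nM. Compound 2 stands second highest of the three numbers; its nearest neighbour is compound 1 and its furthest is compound 3, and both gaps are within the scatter. The recorded steps are a 1.4-fold lower number from compound 1 to compound 2 (0.15 log units; within the scatter), a 2.0-fold lower number from compound 1 to compound 3 (0.30 log units; within the scatter) and a 1.4-fold lower number from compound 2 to compound 3 (0.15 log units; within the scatter); none of them leaves the scatter, so exchanging the group at this carbon has not yet moved the read-out among these three.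

Compound 4 `COc1ncnc2[nH]cc(Sc3cccs3)c12` is not yet measured. Its change from compound 2: methoxy in place of thiophen-2-yl on an aromatic carbon. The step that bears on it most directly is a 1.4-fold lower number from compound 1 to compound 2 (0.15 log units; within the scatter), read in reverse, since it also removes the thiophen-2-yl from the same aromatic carbon; that step was within the scatter. For the measured compounds named here, no measured compound carries methoxy, so the entering group is untested in this set. The expectation is therefore a step of about a 1.4-fold higher number from compound 2 to compound 4 (0.13 log units; within the scatter), not beyond the scatter. Compound 4 is estimated at 22000 nM, with a range from 9000 nM to 55000 nM.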

Compound 4, half-maximal inhibitory concentration: 21500 nM
Compound 4: the middle estimate sits 1.0-fold (0.01 log units) above what was measured, within the range that was stated.
By their numbers in this assay, from the lowest: compounds 3, 2, 4 and 1 (each within the scatter of the next).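

Methoxy brings the set its first oxygen-linked group at this aromatic carbon, and in this assay replacing thiophen-2-yl, a five-membered aromatic ring of 5 heavy atoms, with this ringless group of 2 heavy atoms gives a 1.3-fold higher number from compound 2 to compound 4 (0.12 log units; within the scatter), so a marked cut in group size does not separate the two compounds. The same holds against the other two groups, with a 1.9-fold higher number from compound 3 to compound 4 (0.28 log units; within the scatter) and a 1.1-fold lower number from compound 1 to compound 4 (0.03 log units; within the scatter), which places all four groups at this carbon within the scatter of one another and extends the flat read-out from ring and amino substituents to an ether. No measurement here offers an explanation for this flat read-out.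

A carboxylic acid, a longer chain such as butoxy, or a dimethylamino group at this carbon remains open, so the compounds shown do not establish whether any group here can move the read-out beyond the scatter. Changes elsewhere on the shared core, and whether this flat read-out holds outside this assay, also remain open.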